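Changing the ester side chain of compound 3

The source may hold more compounds than are shown below. What is called first, only, known or untested is meant among the compounds shown, and "the series" means these compounds.

Measured in a functional assay on DU-145 cells (Homo sapiens) for cytotoxicity, read by MTT assay (a lower number here means a stronger inhibitor, a higher number a weaker inhibitor), so far
compound 1 `CC(C)=CC[C@@H](OC[C@H](C)O)C1=CC(=O)c2c(O)ccc(O)c2C1=O` gives 24500 nM
compound 2 `COC(C)CO[C@H](CC=C(C)C)C1=CC(=O)c2c(O)ccc(O)c2C1=O` gives 16600 nM
compound 3 `CC(=O)OCCC(=O)O[C@H](CC=C(C)C)C1=CC(=O)c2c(O)ccc(O)c2C1=O` gives 15700 nM

In this assay compound 3 gives 15700 nM and cannot be separated from the other two compounds. The steps of a 1.1-fold lower number from compound 2 to compound 3 (0.02 log units; within the scatter) and a 1.6-fold lower number from compound 1 to compound 3 (0.19 log units; within the scatter) both stay inside the normal spread of repeated measurements.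

Compound 4 `CCCCC(O)CC(=O)O[C@H](CC=C(C)C)C1=CC(=O)c2c(O)ccc(O)c2C1=O` keeps the shared core and alters only the far part of the side chain. The change is 1-hydroxypentyl in place of acetoxymethyl on a saturated chain carbon bound to a carbonyl carbon and it puts 1-hydroxypentyl in place of acetoxymethyl.

Going by the values given here, no measured compound carries 1-hydroxypentyl, so the data offer no direct precedent. The nearest evidence is how little the numbers moved when this same side chain differed in other ways. Besides the two steps above, the step of a 1.5-fold lower number from compound 1 to compound 2 (0.17 log units; within the scatter) is just as small. Across these three compounds, no side chain change has yet moved the number beyond the scatter, though three compounds are a thin basis.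

The step expected in this assay is a 1.1-fold lower number from compound 3 to compound 4 (0.05 log units; within the scatter) and so no change beyond the scatter is foreseen, in either direction. For compound 4 the estimated value is 14000 nM with 6000 nM to 30000 nM as the expected range.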

Compound 4, half-maximal inhibitory concentration: 45300 nM
Beside the measured number, compound 4's estimate is 3.2-fold (0.51 log units) below it; the measured number lies above the stated range.
By their numbers in this assay, from the lowest: compounds 3, 2, 1 and 4 (each within the scatter of the next, the first and the last beyond it).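

Within this assay, this is the first change in the side chain that goes beyond the scatter (in a 2.9-fold higher number from compound 3 to compound 4 (0.46 log units; beyond the scatter) and in a 2.7-fold higher number from compound 2 to compound 4 (0.44 log units; beyond the scatter)), so the far part of the side chain is not as free to vary as the earlier compounds suggested, and 1-hydroxypentyl in place of acetoxymethyl on a saturated chain carbon bound to a carbonyl carbon gives a weaker inhibitor. The effect does not hold against every compound, however: the step to compound 4 from the ether-linked compound 1 stays within the scatter (a 1.8-fold higher number from compound 1 to compound 4 (0.27 log units; within the scatter)), so those two cannot be told apart. No supporting measurement is available to explain the shift in this number.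

The change swaps more than one feature at once, so the compounds shown leave open whether the longer carbon chain or its hydroxyl goes with the higher number. A plain pentyl group in the same place would separate those two features, and a carboxylic acid or an amine there would show how far this part of the side chain can be pushed.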